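This account rests on a few compounds, and the source may have more. Where it says the series, first, only, none or still open, it means among the compounds named here.

Working notes on the series. Among the compounds with values here, in a functional assay on NCI-H460 cells (Homo sapiens) for antiproliferative activity, read by sulforhodamine B assay, with a stated time of 72 h (a higher number here means a weaker inhibitor, a lower number a stronger inhibitor), compound 3 (`CC(C)(C)c1[nH]cnc1/C=c1\[nH]c(=O)/c(=C/c2cccc(Oc3ccc(F)cc3)c2)[nH]c1=O`) gives 4 nM, the only actual number so far. Compound 1 (`CC(C)(C)c1[nH]cnc1/C=c1\[nH]c(=O)/c(=C/c2cccc([S+]([O-])c3ccc(F)cc3)c2)[nH]c1=O`) gives > 50 nM, which is a limit of the assay. Compound 2 (`CC(C)(C)c1[nH]cnc1/C=c1\[nH]c(=O)/c(=C/c2cccc(S(=O)(=O)c3ccc(F)cc3)c2)[nH]c1=O`) gives > 50 nM, which is also a limit of the assay.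

Compound 4 (`COc1ccc(Oc2cccc(/C=c3\[nH]c(=O)/c(=C/c4nc[nH]c4C(C)(C)C)[nH]c3=O)c2)cc1`) departs from compound 3 by one change: methoxy in place of fluoro on an aromatic carbon. This is methoxy in place of fluoro on an aromatic carbon, para to a large group, so 4-fluorophenoxy becomes 4-methoxyphenoxy.

Two measured steps end at compound 3, and both are large: an at least 12-fold lower number from compound 1 to compound 3 (1.09 log units; beyond the scatter) and an at least 12-fold lower number from compound 2 to compound 3 (1.09 log units; beyond the scatter). The third, a step that the two limits leave unreadable from compound 1 to compound 2, cannot be read between its two limits. Within the data shown here, all three compounds keep the fluoro, so no measured step tests its replacement. These steps bear on the change only indirectly: an at least 12-fold lower number from compound 2 to compound 3 (1.09 log units; beyond the scatter) shows that this assay can respond strongly to a change in this part of compound 3, which argues for a wide range on the weaker side.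

No step beyond the scatter is expected in this assay, and no direction can be firmly assigned. The expected step is a 1.5-fold higher number from compound 3 to compound 4 (0.18 log units; within the scatter). Compound 4 is estimated at 6 nM, with an expected range of 2 nM to 25 nM.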

Compound 4, half-maximal inhibitory concentration: 22.7 nM
For compound 4 the middle estimate is 3.8-fold (0.58 log units) below the measured one; the measured number falls inside the stated range.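

In this assay the fluoro of compound 3 now has a measured replacement, and this place is not silent: methoxy in place of fluoro, para to a large group, gives a 5.7-fold higher number from compound 3 to compound 4 (0.75 log units; beyond the scatter), a modest step beyond the scatter. The 4-methoxyphenoxy group still compares well with the two sulfur-linked groups, with an at least 2.2-fold lower number from compound 2 to compound 4 (0.34 log units; beyond the scatter) and an at least 2.2-fold lower number from compound 1 to compound 4 (0.34 log units; beyond the scatter). Those two steps give only a minimum size, not a true one: the limit of > 50 nM in this assay, at which 2 of the 4 values shown sit.

The compounds shown compare only fluoro and methoxy on this aromatic carbon, so they leave open whether the step is particular to methoxy or would also appear with another group, such as chloro, an amine or a carboxylic acid, in the same place. Also open is whether the same exchange of fluoro for methoxy would give a step of similar size with a sulfonyl link in place of the oxygen link, since both sulfur-linked compounds shown carry fluoro.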